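The source may report more compounds than this note shows. Statements on the series, on what has been measured and on what is new or still open speak of the compounds shown alone.

Measured compounds:
compound 1, `CC(NC(=O)/C=C/c1ccc(NC(=O)Nc2ccc(Cl)c(C(F)(F)F)c2)cc1)c1ccccc1`: 12200 nM
compound 2, `CNC(=O)/C=C/c1ccc(NC(=O)Nc2ccc(Cl)c(C(F)(F)F)c2)cc1`: 20400 nM
compound 3, `CNC(=O)/C=C(\C)c1ccc(NC(=O)Nc2ccc(Cl)c(C(F)(F)F)c2)cc1`: > 50000 nM

The three measured compounds were tested in a functional assay on HepG2 cells (Homo sapiens) for inhibition, read by MTT assay, with a stated time of 120 h; on this read-out lower numbers stand for stronger inhibition and higher numbers for weaker inhibition. In this assay compound 1 gives 12200 nM and compound 2 gives 20400 nM. For compound 3 this assay reports only a limit, > 50000 nM, which is the limit described as the limit of > 50000 nM in this assay, at which 1 of the 3 values shown sits.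

Compound 2 and compound 1 differ in one place, (1-phenylethyl in place of methyl on an amide-type nitrogen); the step is a 1.7-fold lower number from compound 2 to compound 1 (0.22 log units; within the scatter). Compound 2 and compound 3 differ in their cores, (1-methyl-2-(methylcarbamoyl)ethenyl in place of 2-(methylcarbamoyl)ethenyl on an aromatic carbon); the step is an at least 2.4-fold higher number from compound 2 to compound 3 (0.38 log units; beyond the scatter).

Compound 4, `C/C(=C\C(=O)NC(C)c1ccccc1)c1ccc(NC(=O)Nc2ccc(Cl)c(C(F)(F)F)c2)cc1`, has not yet been measured. It differs from compound 3 by 1-phenylethyl in place of methyl on an amide-type nitrogen. This is the same change that was made from compound 2 to compound 1, and it sits in the same place in both pairs. Since that earlier step was a 1.7-fold lower number from compound 2 to compound 1 (0.22 log units; within the scatter), the step from compound 3 to compound 4 is expected to be of similar, small size, an at least 1.1-fold lower number from compound 3 to compound 4 (0.04 log units; that floor lies within the scatter). The estimate for compound 4 in this assay is therefore 45000 nM, with a range from 18000 nM to 150000 nM, and it is expected that this assay may again report only a limit, as it did for compound 3 with > 50000 nM.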

Compound 4, half-maximal inhibitory concentration: > 50000 nM
Compound 4 ended at the assay's limit (the forecaster's own chance of this, stated with the estimate: 55%); middle value at least 1.1-fold (0.04 log units) away from the limit.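

In this assay, compound 3 and compound 4 both stand at the assay's limit, so no step between the two can be read: the limit of > 50000 nM in this assay, at which 2 of the 4 values shown sit.

The compounds shown leave open how far past that limit the true values of compound 3 and compound 4 lie, and whether 1-phenylethyl in place of methyl on the amide-type nitrogen changes anything in this pair.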